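Shortening the alkyl chain on a thienopyrimidinone series

The compounds below may be only part of what the source reports. "The series", "measured", "known", "first", "only" and "open" are said of these compounds alone.

Compounds measured so far:
- compound 1, `CCCCCCc1cc2c(=O)n(CCCSc3nc(-c4cc(OC)c(OC)c(OC)c4)c(C#N)c(=O)[nH]3)cnc2s1`: 54.3 ug/mL
- compound 2, `N#Cc1c(-c2ccc(O)cc2)[nH]c(=S)[nH]c1=O`: 93 ug/mL
- compound 3, `CCCCCCCc1cc2c(=O)n(CCSc3nc(-c4cc(OC)c(OC)c(OC)c4)c(C#N)c(=O)[nH]3)cnc2s1`: 88.1 ug/mL

In an ADME assay on THP-1 cells (Homo sapiens) for inhibition, read by MTT assay (on this read-out lower numbers stand for stronger inhibition of growth and higher numbers for weaker inhibition of growth), compound 1 gives 54.3 ug/mL, the lowest of the three numbers, yet compound 3 with 88.1 ug/mL and compound 2 with 93 ug/mL both lie within the usual scatter of it, so no ordering among the three can be claimed. No pair of these compounds differs in a single place, so no measured step is available to guide the next change.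

Compound 4, `CCCc1cc2c(=O)n(CCCSc3nc(-c4cc(OC)c(OC)c(OC)c4)c(C#N)c(=O)[nH]3)cnc2s1`, has not been measured in this assay. It differs from compound 1 by hydrogen in place of propyl on a saturated chain carbon, three bonds along the chain from an aromatic carbon; cut one bond further out, the same difference reads hexyl to propyl. Within the data shown here, with no measured step of this kind, the expectation is that going from compound 1 to compound 4 in this assay gives no change beyond the scatter, a 1.2-fold higher number from compound 1 to compound 4 (0.08 log units; within the scatter). Compound 4 is therefore estimated at 65 ug/mL, with a range from 30 ug/mL to 140 ug/mL.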

Compound 4, concentration for 50% growth inhibition: > 100 ug/mL
Compound 4: a limit, no number; the forecaster's own chance of this, stated with the estimate: 10%; middle value at least 1.5-fold (0.18 log units) away from the limit.
By their numbers in this assay, from the lowest: compounds 1, 3 and 2 (each within the scatter of the next). At a limit, above all of these: compound 4.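

In this assay compound 4 gives > 100 ug/mL, which is a limit of the assay and not a number. Among these compounds, this is the first single-place step, hexyl to propyl on the chain, and it reads an at least 1.8-fold higher number from compound 1 to compound 4 (0.26 log units; that floor lies within the scatter), so shortening the chain gave no lower number, though the floor of the step does not clear the scatter. The true size of the step stays unknown because the value of compound 4 rests at the ceiling of the read-out: the limit of > 100 ug/mL in this assay, at which 1 of the 4 values shown sits.

The compounds shown leave open how butyl or pentyl at this position would read, and whether a longer chain such as octyl, or an amine at the chain end, would give a lower number. Compound 3 differs from compound 1 in more than one place, so it does not settle the role of chain length.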